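A few compounds are considered here, and "the series" means these few. Any claim that something is new, unique, unknown or untested is made for them only; others in the source may bear on it.

Measured so far:
compound 1 `Cc1cc(C(=O)NCN2CCC(c3cccc[n+]3[O-])CC2)ccc1F`: 67%
compound 2 `O=C(CN1CCC(c2cccc[n+]2[O-])CC1)Nc1ccc(F)cc1C(F)(F)F`: 65%

In a functional assay on HEK293 cells for agonist activity at D(4) dopamine receptor (Homo sapiens), read by FLIPR (on this read-out lower numbers stand for smaller maximal responses and higher numbers for larger maximal responses), compound 1 gives the higher of the two numbers, yet compound 2 at 65% lies within the scatter, so the two cannot be told apart. Compound 3 `O=C(NCN1CCC(c2cccc[n+]2[O-])CC1)c1cc(Cl)cc(Cl)c1` is not yet measured. It differs from compound 1 by 3,5-dichlorophenyl in place of 4-fluoro-3-methylphenyl on a carbonyl carbon. Among the measured compounds shown here, no measured pair differs in one place, so nothing yet shows what such a change does. Both measured compounds sit near one level in this assay, and the expected step is a number 3 percentage points lower from compound 1 to compound 3 (within the scatter), not beyond the scatter in either direction. Compound 3 is estimated at 64%, range 45% to 80%.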

Compound 3, largest response reached (reported as efficacy), in percent of the reference or control that the assay uses: 64%
Estimate against measurement, compound 3: no gap at the digits printed, within the range that was stated.
By their numbers in this assay, from the lowest: compounds 3, 2 and 1 (each within the scatter of the next).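

In this assay, among the compounds shown here, 3,5-dichlorophenyl in place of 4-fluoro-3-methylphenyl on a carbonyl carbon gives a number 3 percentage points lower from compound 1 to compound 3 (within the scatter) as the first step that can be read at a single position. At this position, an aryl group bearing two chlorine atoms therefore cannot be told apart from one bearing fluorine and methyl. No accompanying measurement bears on this result. Open, on these data alone, is whether a cyclohexyl group, or a phenyl ring carrying an amine or a carboxylic acid, on this carbonyl carbon would shift the response beyond the scatter.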